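A few compounds are considered here, and "the series" means these few. Any claim that something is new, unique, unknown or untested is made for them only; others in the source may bear on it.

Measured so far in an ADME assay on CHO cells (Cricetulus griseus) for inhibition, read by MTT assay; a lower number here means a stronger inhibitor, a higher number a weaker inhibitor:
Compound 1 `CCN(CC)Cc1cc(Nc2nc3ccccc3n2Cc2ccc(C#N)cc2)ccc1O` gives > 50000 nM, which is a limit of this assay and not a number.
Compound 2 `CCN(CC)Cc1ccc(C)c(Nc2nc3ccccc3n2Cc2ccc(F)cc2)c1O` gives > 50000 nM, again a limit.
Compound 3 `CCNCc1cc(Cl)cc(Nc2nc3ccccc3n2Cc2ccc(C(F)(F)F)cc2)c1O` gives 33800 nM.

Compound 1 therefore stands not at a measured number but at the limit of > 50000 nM in this assay, at which 2 of the 3 values shown sit, and compound 2 stands there with it, while only compound 3 has a numerical read-out, itself a weak one. Compound 4 `CCN(CC)Cc1cc(Nc2nc3ccccc3n2Cc2ccc(F)cc2)ccc1O` differs from compound 1 in a single place: fluoro in place of cyano on an aromatic carbon. Among the compounds with values here, no pair of measured compounds shows how this change acts in this assay, and compound 2, which also carries fluoro, sits at the same limit as compound 1. The step from compound 1 to compound 4 in this assay is expected to be none beyond the scatter, a step that the limit leaves unreadable from compound 1 to compound 4. Compound 4 is estimated to give 60000 nM, with a range from 20000 nM to 200000 nM, and most likely this assay will report only a limit for it.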

Compound 4, half-maximal inhibitory concentration: 12000 nM
For compound 4 the middle estimate is 5.0-fold (0.70 log units) above the measured one; measured number outside the range, below it.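

Replacing the nitrile with fluoro on the 4-cyanobenzyl group brings, in this assay, an at least 4.1-fold lower number from compound 1 to compound 4 (0.61 log units; beyond the scatter). Within the data shown here, this shows that the group at this place, para to a large group, can bring the read-out down from the limit to a measured number, which the earlier compounds, with no pair differing in one place, could not show. The full size of the step cannot be read, since compound 1 gives only a limit and not a number, a limit that is common in this small set: the limit of > 50000 nM in this assay, at which 2 of the 4 values shown sit.

On these data alone, how a hydrogen, a methoxy group or a carboxylic acid at this place would compare stays open, and so does whether the step belongs to the loss of the nitrile or to the arrival of fluoro. Equally open, as far as these compounds go, is whether the same change would act alike if the diethylamine gave way to a morpholine.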